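The source may report more compounds than this note shows. Statements on the series, on what has been measured and on what is new or still open speak of the compounds shown alone.

Measured compounds in an assay on lysate for inhibition of 6-phosphofructo-2-kinase/fructose-2,6-bisphosphatase 3 (Homo sapiens), with stated times of 0.5 min and 45 min; on this read-out lower numbers stand for stronger inhibition and higher numbers for weaker inhibition:
compound 1 `CN1CCCC(NS(=O)(=O)c2ccccc2Nc2cc(-c3ccc4ccn(C)c4c3)c3nccnc3c2)C1` gives 9780 nM.
compound 2 `CN(Cc1cncnc1)S(=O)(=O)c1ccccc1Nc1cc(-c2ccc3ccn(C)c3c2)c2nccnc2c1` gives a limit of the assay, > 100000 nM.
compound 3 `CN(C)C(=O)c1ccncc1Nc1cc(-c2ccc3ccn(C)c3c2)c2nccnc2c1` gives a limit of the assay, > 100000 nM.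

As far as these compounds go, compound 3 thus stands at the limit of > 100000 nM in this assay, at which 2 of the 3 values shown sit; its true value is unknown, and no numbered step can be drawn from it. Among the compounds with values here, the one measured step is an at least 10-fold higher number from compound 1 to compound 2 (1.00 log units; beyond the scatter), a change on the sulfonyl sulfur of a different linker, in which the ring amine of compound 1 gives way to an acyclic amine and the number rises beyond the scatter.

Compound 4 `CN1CC(NC(=O)c2ccncc2Nc2cc(-c3ccc4ccn(C)c4c3)c3nccnc3c2)CCC1=O` differs from compound 3 by (1-methyl-6-oxopiperidin-3-yl)amino in place of dimethylamino on a carbonyl carbon. This brings in a ring amine of the kind compound 1 carries on its sulfonyl sulfur, with an added carbonyl in the ring, and removes the acyclic amine that compound 3 shares in spirit with compound 2. The step from compound 1 to compound 2 bears on it only by analogy, since the linker differs. A drop in the number is expected, so compound 4 is estimated at 30000 nM, between 5000 nM and 100000 nM, meaning an expected step of an at least 3.3-fold lower number from compound 3 to compound 4 (0.52 log units; beyond the scatter), with a real chance that only a limit is reported.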

Compound 4, half-maximal inhibitory concentration: 96500 nM
Estimate against measurement, compound 4: 3.2-fold (0.51 log units) below, within the range that was stated.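

With (1-methyl-6-oxopiperidin-3-yl)amino on the carbonyl carbon, this position gives its first exact reading: in this assay compound 4 gives 96500 nM. Compound 3 remains a limit of the assay, so the true size of this change stays unfixed because of where that value sits: the limit of > 100000 nM in this assay, at which 2 of the 4 values shown sit. The step can only be read as an at least 1.0-fold lower number from compound 3 to compound 4 (0.01 log units; that floor lies within the scatter), so this larger ring-bearing amine on the carbonyl carbon shows no gain beyond the scatter over dimethylamino.

Still open, as far as these compounds go, is how a 1-methylpiperidin-3-ylamino group without the ring carbonyl, or a simple primary aminoethyl chain, would read on this carbonyl carbon. From the compounds shown here alone, whether one and the same amine reads alike on the sulfonyl sulfur and on the carbonyl carbon also stays open.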